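A few compounds are considered here, and "the series" means these few. Any claim that something is new, unique, unknown or untested is made for them only; others in the source may bear on it.

Measured so far:

Compound 1, `O=C(Nc1cccc(OCc2cn(-c3ccccc3)nn2)c1)Nc1ccc(Cl)c(C(F)(F)F)c1`: 1780 nM in a functional assay on HepG2 cells (Homo sapiens) for inhibition, read by MTT assay, with a stated time of 72 h; a higher number here means a weaker inhibitor, a lower number a stronger inhibitor
Compound 2, `Cc1ccc(-n2cc(COc3cccc(NC(=O)Nc4ccc(Cl)c(C(F)(F)F)c4)c3)nn2)cc1`: 5430 nM
Compound 3, `CC(C)c1ccccc1-n1cc(COc2cccc(NC(=O)Nc3ccc(Cl)c(C(F)(F)F)c3)c2)nn1`: 1900 nM

Compound 3 gives the second highest of the three numbers. Its nearest neighbour is compound 1, with a step of a 1.1-fold higher number from compound 1 to compound 3 (0.03 log units; within the scatter); its furthest is compound 2, with a step of a 2.9-fold lower number from compound 2 to compound 3 (0.46 log units; beyond the scatter). The next compound, compound 4, is `O=C(Nc1cccc(OCc2cn(-c3cccc(Cl)c3)nn2)c1)Nc1ccc(Cl)c(C(F)(F)F)c1`. It differs from compound 3 by 3-chlorophenyl in place of 2-isopropylphenyl on an aromatic nitrogen.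

Among the compounds with values here, three measured steps concern the same phenyl group on the aromatic nitrogen. The step of a 3.1-fold higher number from compound 1 to compound 2 (0.48 log units; beyond the scatter) weakened inhibition modestly, whereas a 1.1-fold higher number from compound 1 to compound 3 (0.03 log units; within the scatter) changed little, and a 2.9-fold lower number from compound 2 to compound 3 (0.46 log units; beyond the scatter) recovered that loss. None of them places a chlorine on this ring, so the direction for compound 4 is uncertain; the measured steps were all small to modest, so a comparable size is expected here, with a slight weakening estimated as a 1.3-fold higher number from compound 3 to compound 4 (0.12 log units; within the scatter). For compound 4 the estimated value in this assay is 2500 nM, within an expected range of 1000 nM to 6500 nM.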

Compound 4, half-maximal inhibitory concentration: 2020 nM
The estimate for compound 4 lay 1.2-fold (0.09 log units) above the measured number, within the range that was stated.
By their numbers in this assay, from the lowest: compounds 1, 3 and 4 (each within the scatter of the next); then compound 2.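

Within the data shown here, compound 4 puts a chloro group on this phenyl ring, a kind of substituent the earlier compounds did not carry, and in this assay it makes no difference beyond the scatter from the unsubstituted ring: a 1.1-fold higher number from compound 1 to compound 4 (0.05 log units; within the scatter). Exchanging 2-isopropylphenyl for 3-chlorophenyl likewise stays within the scatter, with a 1.1-fold higher number from compound 3 to compound 4 (0.03 log units; within the scatter), so among these compounds only the 4-methylphenyl group of compound 2 stands apart, with a 2.7-fold lower number from compound 2 to compound 4 (0.43 log units; beyond the scatter). No measurement shown gives a reason for these numbers.

The compounds shown leave open whether an amine, a carboxylic acid or a methoxy group on this phenyl ring would shift the number beyond the scatter, as the 4-methylphenyl group does. They also leave open how a pyridine ring in place of the phenyl ring on the aromatic nitrogen would compare.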